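A few compounds are considered here, and "the series" means these few. Any claim that something is new, unique, unknown or untested is made for them only; others in the source may bear on it.

Compound 1 `CCCCCCCCCCCCCCNC(=O)[C@@H](NC(=O)c1cc2ccccc2[nH]1)[C@@H](C)O` gives 10500 nM in a functional assay on HepG2 cells (Homo sapiens) for cytotoxicity, read by MTT assay, with a stated time of 48 h; on this read-out higher numbers stand for weaker inhibition and lower numbers for stronger inhibition. Compound 2 `CCCCCCCCCCCCCCNC(=O)[C@@H](NC(=O)/C=C/c1ccccc1)[C@@H](C)O` gives 150000 nM, after a step of a 14-fold higher number from compound 1 to compound 2 (1.15 log units; beyond the scatter). Compound 3 `C/C=C/C=C/C(=O)N[C@H](C(=O)NCCCCCCCCCCCCCC)[C@@H](C)O` records only > 400000 nM, which is the limit of this assay (the limit of > 400000 nM in this assay, at which 1 of the 3 values shown sits). Compound 3 therefore stands at the weak end of the three, since both an at least 38-fold higher number from compound 1 to compound 3 (1.58 log units; beyond the scatter) and an at least 2.6-fold higher number from compound 2 to compound 3 (0.42 log units; beyond the scatter) run toward higher numbers. Compound 4 `CCCCCCCCCCCCCCNC(=O)[C@@H](NS(=O)(=O)c1ccc(C)cc1)[C@@H](C)O` differs from compound 3 by (4-methylphenyl)sulfonyl in place of (penta-1,3-dien-1-yl)carbonyl on an amine nitrogen. The two measured steps that removed an aromatic ring both raised the number, the first large and the second at least modest. Reintroducing a six-membered aromatic ring is accordingly expected to lower the number, a step of an at least 2.6-fold lower number from compound 3 to compound 4 (0.42 log units; beyond the scatter). Compound 4 is estimated at 150000 nM, with a range from 30000 nM to 400000 nM.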

Compound 4, half-maximal inhibitory concentration: 10900 nM
The estimate for compound 4 lay 14-fold (1.14 log units) above the measured number; the measured number lies below the stated range.
By their numbers in this assay, from the lowest: compounds 1 and 4 (each within the scatter of the next); then compound 2. At a limit, above all of these: compound 3.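

On this amine nitrogen, (4-methylphenyl)sulfonyl gives a 14-fold lower number from compound 2 to compound 4 (1.14 log units; beyond the scatter), although (2-phenylethenyl)carbonyl also holds a six-membered aromatic ring, so such a ring alone does not set the number. The step of an at least 36-fold lower number from compound 3 to compound 4 (1.56 log units; beyond the scatter) is read against a limit of the assay: the limit of > 400000 nM in this assay, at which 1 of the 4 values shown sits. Among these compounds, the step of a 1.0-fold higher number from compound 1 to compound 4 (0.02 log units; within the scatter) shows that (1H-indol-2-yl)carbonyl is not the only group on this nitrogen to reach this level.

The compounds shown do not separate the sulfonyl link from the 4-methylphenyl group it carries. A benzoyl or a methylsulfonyl group on this nitrogen would separate them.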